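The source may hold more compounds than are shown below. What is called first, only, known or untested is meant among the compounds shown, and "the series" means these compounds.

Working notes on the thiocarbamate series.

Compound 1 `O=c1cc(CSC(=S)N2CCCC2)oc2ccccc12` is the reference point. In a functional assay on MCF7 cells (Homo sapiens) for antiproliferative activity, read by MTT assay, with a stated time of 72 h (on this read-out higher numbers stand for weaker inhibition and lower numbers for stronger inhibition), compound 1 gives 35800 nM. Compound 2 `O=c1cc(CSC(=S)N2CCCCC2)oc2ccccc12` carries the change (piperidin-1-yl in place of pyrrolidin-1-yl on a thiocarbonyl carbon). Compound 2 gives > 25000 nM in this assay, which is a limit of the assay and not a number. The step that the limit leaves unreadable from compound 1 to compound 2 therefore cannot be read in size, because the limit of > 25000 nM in this assay, at which 1 of the 3 values shown sits, sits on one end of it.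

Compound 3 `COc1ccc2occ(CSC(=S)N3CCCC3)c(=O)c2c1` has a different core from compound 1; the difference between the two cores is not broken down here. In this assay compound 3 gives 34100 nM, and the gap between compound 3 and compound 1 lies within the usual scatter of repeated measurements.

Compound 4 `COc1ccc2occ(CSC(=S)N3CCCCC3)c(=O)c2c1` is not yet measured in this assay. Relative to compound 3 it carries piperidin-1-yl in place of pyrrolidin-1-yl on a thiocarbonyl carbon. This is the same change as that from compound 1 to compound 2, made at the same place, a thiocarbonyl carbon whose other neighbour is sulfur. Among the compounds with values here, for the step from compound 3 to compound 4 there is only one precedent. That precedent is a step that the limit leaves unreadable from compound 1 to compound 2, and that step is unreadable; what can be said is that the change did not move compound 2 to a readable number. The expected step of a 1.2-fold higher number from compound 3 to compound 4 (0.07 log units; within the scatter) for compound 4 is therefore estimated from the direction the precedent points, with a real chance that the assay again returns only a limit. Compound 4 is expected to give about 40000 nM in this assay, within 20000 nM to 90000 nM.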

Compound 4, half-maximal inhibitory concentration: > 40000 nM
Compound 4: no number, only a limit; the forecaster's own chance of this, stated with the estimate: 55%; the middle value lies on the limit itself.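

In this assay the change from pyrrolidin-1-yl to piperidin-1-yl on a thiocarbonyl carbon gives an at least 1.1-fold higher number from compound 3 to compound 4 (0.06 log units; that floor lies within the scatter) on the core of compound 3, so this floor alone does not show a shift beyond the usual scatter. Compound 4 returns a limit of the assay and not a number: the limit of > 40000 nM in this assay, at which 1 of the 4 values shown sits. Within the data shown here, on the core of compound 1 the same change leads to compound 2, which also returns a limit and not a number, so the pair of results shows only that the change yielded no readable value on either core, and it does not show how large the step is on either core or whether its size carries from one core to the other: the limit of > 25000 nM in this assay, at which 1 of the 4 values shown sits.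

The compounds shown leave open how morpholin-4-yl or diethylamino in place of pyrrolidin-1-yl on a thiocarbonyl carbon would read in this assay on either core. Also open, as far as these compounds go, is whether such a group would give a readable step on both cores, which would allow the change to be compared in size from one core to the other.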